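From Piperazine to Phenyltetrazole: What to Expect of Compound 4

The compounds below may be only part of what the source reports. "The series", "measured", "known", "first", "only" and "open" are said of these compounds alone.

Of the compounds shown here, three sharing one core have been measured in a functional assay on HUVEC cells (Homo sapiens), read by scintillation counting and thymidine incorporation, with a stated time of 24 h; a higher number here means a weaker inhibitor, a lower number a stronger inhibitor. Compound 1 `CCC(C)n1ncn(-c2ccc(N3CCN(c4ccc(OC[C@@H]5CO[C@@](CC)(c6ccc(Cl)cc6Cl)O5)cc4)CC3)cc2)c1=O` gives 353 nM, compound 2 `CCC(C)n1ncn(-c2ccc(N3CCN(c4ccc(OC[C@@H]5CO[C@@](CN6CCNCC6)(c6ccc(Cl)cc6Cl)O5)cc4)CC3)cc2)c1=O` gives 608 nM, and compound 3 `CCC(C)n1ncn(-c2ccc(N3CCN(c4ccc(OC[C@@H]5CO[C@@](Cn6nc(C)nc6C)(c6ccc(Cl)cc6Cl)O5)cc4)CC3)cc2)c1=O` gives 221 nM. Compound 2 carries the highest of the three numbers: its nearest neighbour is compound 1, a gap within the scatter, while compound 3 lies beyond it, as the step of a 2.8-fold lower number from compound 2 to compound 3 (0.44 log units; beyond the scatter) shows. The other two steps, a 1.7-fold higher number from compound 1 to compound 2 (0.24 log units; within the scatter) and a 1.6-fold lower number from compound 1 to compound 3 (0.20 log units; within the scatter), stay within the scatter.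

Compound 4 `CCC(C)n1ncn(-c2ccc(N3CCN(c4ccc(OC[C@@H]5CO[C@@](Cn6nnnc6-c6ccccc6)(c6ccc(Cl)cc6Cl)O5)cc4)CC3)cc2)c1=O` is obtained from compound 2 by one change: 5-phenyl-1H-tetrazol-1-yl in place of piperazin-1-yl on a saturated chain carbon bound to a saturated ring carbon

Within the data shown here, the step that bears most directly on this is the one from compound 2 to compound 3, where a five-membered aromatic azole took the place of the same piperazin-1-yl and the number fell modestly. Among the measured compounds shown here, compound 4 also puts an aromatic azole there, though a larger one with a pendant phenyl, for which there is no measured precedent. On that basis a modest fall of similar size is expected, a 2.3-fold lower number from compound 2 to compound 4 (0.37 log units; beyond the scatter), with wide uncertainty. Compound 4 is therefore estimated at 260 nM, within a range of 90 nM to 750 nM.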

Compound 4, half-maximal inhibitory concentration: 119 nM
Compound 4: the middle estimate sits 2.2-fold (0.34 log units) above what was measured; measured number inside the range.
By their numbers in this assay, from the lowest: compounds 4, 3, 1 and 2 (each within the scatter of the next, the first and the last beyond it).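

In this assay, 5-phenyl-1H-tetrazol-1-yl on the saturated chain carbon bound to a saturated ring carbon gives a 5.1-fold lower number from compound 2 to compound 4 (0.71 log units; beyond the scatter) and also a 3.0-fold lower number from compound 1 to compound 4 (0.47 log units; beyond the scatter) so that, unlike the triazole of compound 3, whose step from the methyl of compound 1 stays within the scatter, this aromatic azole stands clear of both the piperazine and the methyl. The position therefore accepts a group of 11 heavy atoms with a pendant phenyl and loses nothing against the smaller 3,5-dimethyl-1H-1,2,4-triazol-1-yl, as a 1.9-fold lower number from compound 3 to compound 4 (0.27 log units; within the scatter) stays within the scatter and leaves these two azoles unseparated. Nothing available here explains why the number moves with this change.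

The compounds shown leave open whether the tetrazole ring or its phenyl accounts for the step, a question that an unsubstituted 1H-tetrazol-1-yl or a 5-methyl-1H-tetrazol-1-yl at the same place would address. They also leave open how a benzyl group, a carboxylic acid or a longer chain would read at this position, and whether a substituted phenyl on the tetrazole would move the number further.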